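Chain extension in a trimethoxybiphenyl diketopiperazine series

This account rests on a few compounds, and the source may have more. Where it says the series, first, only, none or still open, it means among the compounds named here.

Measured so far in a functional assay for agonist activity at follicle-stimulating hormone receptor (Homo sapiens), read by a luciferase reporter; on this read-out higher numbers stand for an effect only at larger amounts of compound and lower numbers for an effect already at smaller amounts:
- compound 1 `CCCCCCCCCN1CC(=O)N(C)[C@@H](Cc2ccc(-c3cc(OC)c(OC)c(OC)c3)cc2)C1=O`: 900 nM
- compound 2 `CCCCCCCCN1CC(=O)N(C)[C@@H](Cc2ccc(-c3cc(OC)c(OC)c(OC)c3)cc2)C1=O`: 400 nM
- compound 3 `CCCCCCN1C(=O)[C@H](Cc2ccc(-c3cc(OC)c(OC)c(OC)c3)cc2)N(C)C(=O)[C@@H]1C`: 100 nM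

Compound 3 gives the lowest number of the three; the difference between its core and that of compound 2 is not broken down here. Within the core of compound 2, the change methyl in place of hydrogen on a saturated chain carbon, eight bonds along the chain from an amide-type nitrogen in a ring gives the step of a 2.3-fold higher number from compound 2 to compound 1 (0.35 log units; beyond the scatter).

Compound 4 `CCCCCCCN1C(=O)[C@H](Cc2ccc(-c3cc(OC)c(OC)c(OC)c3)cc2)N(C)C(=O)[C@@H]1C` has not been measured. It differs from compound 3 by methyl in place of hydrogen on a saturated chain carbon, six bonds along the chain from an amide-type nitrogen in a ring. This is the same kind of change as from compound 2 to compound 1, but the place differs: six bonds along the chain from the ring nitrogen rather than eight. A step of similar direction and size, a 1.8-fold higher number from compound 3 to compound 4 (0.26 log units; within the scatter), is expected, resting on a 2.3-fold higher number from compound 2 to compound 1 (0.35 log units; beyond the scatter). Compound 4 is estimated at 180 nM, between 70 nM and 450 nM.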

Compound 4, half-maximal effective concentration: 25 nM
The estimate for compound 4 lay 7.2-fold (0.86 log units) above the measured number; the whole stated range lies above it.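

In this assay, methyl in place of hydrogen on a saturated chain carbon, six bonds along the chain from an amide-type nitrogen in a ring, gives a 4.0-fold lower number from compound 3 to compound 4 (0.60 log units; beyond the scatter). Chain extension therefore does not carry over as one fixed effect between these two cores: the same change on two cores in this assay, a 2.3-fold higher number (0.35 log units; beyond the scatter) from compound 2 to compound 1 and a 4.0-fold lower number (0.60 log units; beyond the scatter) from compound 3 to compound 4, 9.0-fold (0.95 log units) apart, beyond the scatter of two such steps. With one pair on each core and the change sitting six bonds along the chain in one pair and eight in the other, the effect of the core cannot be separated from that of the place, and no general rule for the series follows.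

Open, on these data alone, is whether a longer chain on the core of compound 4 lowers the number further or raises it. Also open, as far as these compounds go, is how a chain ending in a hydroxyl group or an amine reads in this assay.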